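A few compounds are considered here, and "the series" means these few. Any claim that something is new, unique, unknown or untested is made for them only; others in the source may bear on it.

Measured compounds:
- compound 1 `CN1CCN(c2nc(Cl)nc3c2ncn3Cc2ccc(C(=O)Nc3ccccc3N)cc2)CC1`: 60.4%
- compound 2 `CCCCn1cnc2c(Nc3ccccc3)nc(NCOCc3ccc(/C=C/C(=O)Nc4ccccc4N)cc3)nc21`: 27.9%

In a functional assay on HepG2 cells (Homo sapiens) for antiproliferative activity, read by CCK-8 assay, with a stated time of 72 h, tested at 2 uM (a lower number here means a weaker effect, a higher number a stronger effect of the compound at the concentration tested), compound 1 gives 60.4%, the higher of the two numbers; compound 2 gives 27.9%, a gap beyond the usual scatter. Compound 3 `Nc1ccccc1NC(=O)c1ccc(Cn2cnc3c(Nc4cccc(OC(F)(F)F)c4)nc(Cl)nc32)cc1` is not yet measured. It differs from compound 1 by (3-(trifluoromethoxy)phenyl)amino in place of 4-methylpiperazin-1-yl on an aromatic carbon. Among the compounds with values here, no single-point step between measured compounds is known, so the size of this change must be guessed. The step of a number 12.4 percentage points lower from compound 1 to compound 3 (beyond the scatter) is expected to be modest and downward, not certainly beyond the scatter. For compound 3 the expected value in this assay is 48%, with a range from 22% to 72%.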

Compound 3, a percentage reported as inhibition, at one concentration (the size of the read-out at that concentration, not a potency): 1.88%
Compound 3: the middle estimate sits 46.1 percentage points above what was measured; measured number below the stated range.
By their numbers in this assay, from the lowest: compound 3; then compound 2; then compound 1.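

With (3-(trifluoromethoxy)phenyl)amino in place of 4-methylpiperazin-1-yl on this aromatic carbon next to the ring nitrogen, this assay shows a number 58.5 percentage points lower from compound 1 to compound 3 (beyond the scatter) on the core of compound 1. This gives the series its first single-place step and shows that the read-out is highly sensitive to the group at this position. No available evidence accounts for the size of this step.

On these data alone, it remains open which part of the entering group goes with the drop: the amino link, the phenyl ring or the trifluoromethoxy group. Morpholin-4-yl and (3-methoxyphenyl)amino at this position would help separate these parts.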